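Adding a Chloro to the Phenyl of Compound 3

The source may report more compounds than this note shows. Statements on the series, on what has been measured and on what is new or still open speak of the compounds shown alone.

Of the compounds shown here, three have been measured in an assay on CHO cells for agonist activity at Free fatty acid receptor 1 (Homo sapiens), read by FLIPR; on this read-out higher numbers stand for an effect only at larger amounts of compound and lower numbers for an effect already at smaller amounts. Compound 1 `O=C(O)COc1ccc(OCc2nnc(-c3ccccc3)s2)cc1F` gives a result that is only a limit of the assay, > 10000 nM. Compound 2 `Cc1cc(OCc2nnc(-c3ccccc3)s2)ccc1OCC(=O)O` likewise gives only a limit, > 10000 nM. The step that the two limits leave unreadable from compound 1 to compound 2, methyl in place of fluoro on an aromatic carbon, cannot be sized because of the limit of > 10000 nM in this assay, at which 2 of the 3 values shown sit. Going by the values given here, compound 3 `Cc1nc(-c2ccccc2)sc1COc1ccc2c(c1)OCC2CC(=O)O` is the only one with a number: in this assay compound 3 gives 102 nM. It thus stands alone among the numbers shown, the two other results being limits rather than numbers.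

Compound 4 `Cc1nc(-c2ccc(Cl)cc2)sc1COc1ccc2c(c1)OCC2CC(=O)O` has not yet been measured. It differs from compound 3 by chloro in place of hydrogen on an aromatic carbon, in words chloro in place of hydrogen on an aromatic carbon, para to a large group. Among the compounds with values here, none of the measured steps involves this change or this part of the molecule; the one measured step, between compound 1 and compound 2, concerns a different ring and is unreadable anyway. There is thus no ground for expecting a step beyond the usual scatter in this assay. The step from compound 3 to compound 4 is expected to be a 1.3-fold lower number from compound 3 to compound 4 (0.11 log units; within the scatter). Compound 4 is estimated to give about 80 nM, within a range from 25 nM to 300 nM.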

Compound 4, half-maximal effective concentration: 105 nM
The estimate for compound 4 lay 1.3-fold (0.12 log units) below the measured number; low and high end bracket the measured number.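

In this assay, putting a chloro in place of hydrogen on the phenyl ring gives a 1.0-fold higher number from compound 3 to compound 4 (0.01 log units; within the scatter), so phenyl and 4-chlorophenyl cannot be told apart on this read-out. This is the only readable step among the compounds shown, and it concerns a part of the molecule that no earlier comparison touched: this aromatic carbon, para to a large group, carries a chlorine atom and the compound still gives a number in the same range as compound 3, rather than a limit of the assay. The compounds shown offer no measurement that would explain why this change leaves the read-out where it was.

Going by these compounds, a single substituent at a single position is a narrow test, so it remains open whether a methoxy, a trifluoromethyl or an amine at this same carbon would also leave the number in place, or would shift it beyond the scatter. Going by these compounds alone, it also remains open whether a chloro on one of the other carbons of this phenyl ring would read the same as the one in compound 4.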